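Swapping trifluoromethyl for chloro on a pyrazole cell-growth inhibitor

The source may report more compounds than this note shows. Statements on the series, on what has been measured and on what is new or still open speak of the compounds shown alone.

Of the compounds shown here, three sharing one core have been tested in a functional assay on NCI-H460 cells (Homo sapiens) for inhibition, read by sulforhodamine B assay, with a stated time of 48 h, tested at 10 uM; a lower number here means a stronger effect, a higher number a weaker effect of the compound at the concentration tested. Compound 1 `COc1cc(Cl)cc(-c2nn(-c3cccc(NC(=O)c4ccc(Cl)c(Cl)c4)c3)cc2-c2ccncc2)c1` gives 65.2%. Compound 2 `O=C(Nc1cccc(-n2cc(-c3ccncc3)c(-c3cc(O)cc(Cl)c3)n2)c1)Nc1ccc(Cl)c(Cl)c1` gives 0.21%. Compound 3 `COc1cc(Cl)cc(-c2nn(-c3cccc(NC(=O)Nc4ccc(Cl)c(C(F)(F)F)c4)c3)cc2-c2ccncc2)c1` gives 2.76%, the second highest of the three numbers: its nearest neighbour is compound 2, within the scatter, and its furthest is compound 1, beyond the scatter. Within the data shown here, the one step measured so far, a number 62.4 percentage points lower from compound 1 to compound 3 (beyond the scatter), is large and comes with (4-chloro-3-(trifluoromethyl)phenyl)amino in place of 3,4-dichlorophenyl on a carbonyl carbon.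

Compound 4 `COc1cc(Cl)cc(-c2nn(-c3cccc(NC(=O)Nc4ccc(Cl)c(Cl)c4)c3)cc2-c2ccncc2)c1` differs from compound 3 by chloro in place of trifluoromethyl on an aromatic carbon. Among the measured compounds shown here, no measured step covers exactly this change. Compound 2 carries the same (3,4-dichlorophenyl)amino group and shows a number close to that of compound 3, so little movement is expected. The step of a number 0.2 percentage points higher from compound 3 to compound 4 (within the scatter) is therefore expected to stay within the scatter. Compound 4 is estimated at 3%, with a range from 0% to 15%.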

Compound 4, a percentage reported as activity, at one concentration (the size of the read-out at that concentration, not a potency): 3.1%
For compound 4 the middle estimate is 0.1 percentage points below the measured one; the measured number falls inside the stated range.
By their numbers in this assay, from the lowest: compounds 2, 3 and 4 (each within the scatter of the next); then compound 1.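

In this assay the aromatic carbon ortho to a chloro group accepts either trifluoromethyl with its 4 heavy atoms or chloro with its 1 heavy atom, with no change beyond the scatter (a number 0.3 percentage points higher from compound 3 to compound 4 (within the scatter)). The earlier large step changed two things at once, but now the added amino alone, with 3,4-dichlorophenyl kept, comes with a large step (a number 62.1 percentage points lower from compound 1 to compound 4 (beyond the scatter)). Methyl in place of hydrogen on the oxygen also stays within the scatter (a number 2.9 percentage points higher from compound 2 to compound 4 (within the scatter)).

Nothing measured here explains any of these steps. Going by these compounds, whether a fluoro, a nitrile or a methoxy on that aromatic carbon would keep the number this low stays open, as does any ranking of compound 2, compound 3 and compound 4 at concentrations other than the one tested.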